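Dimethylamino for morpholin-4-yl on a carbonyl carbon

This account rests on a few compounds, and the source may have more. Where it says the series, first, only, none or still open, it means among the compounds named here.

In a physicochemical assay for solubility, read by HPLC (a higher number here means a more soluble compound, a lower number a less soluble compound), compound 3 `COc1ccc([C@H](C(=O)N2CCOCC2)N2C(=O)[C@@H](C3Cc4ccccc4C3)NC(=O)[C@H]2CC(C)C)cn1` gives 249 ug/mL and serves as the starting point here. Compound 2 `CC(C)C[C@@H]1C(=O)N[C@H](C2Cc3ccccc3C2)C(=O)N1[C@@H](C(=O)N(C)C)c1ccc(N(C)C)nc1` gives 233 ug/mL and lies within the scatter of compound 3. Compound 1 `CC(C)C[C@@H]1C(=O)N[C@H](C2Cc3ccccc3C2)C(=O)N1[C@@H](C(=O)N(C)C)c1ccc(O)nc1` reads > 240 ug/mL in this assay and that reading is a limit, not a number.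

Compound 4 `COc1ccc([C@H](C(=O)N(C)C)N2C(=O)[C@@H](C3Cc4ccccc4C3)NC(=O)[C@H]2CC(C)C)cn1` differs from compound 3 by dimethylamino in place of morpholin-4-yl on a carbonyl carbon and the same difference reads (morpholin-4-yl)carbonyl to dimethylcarbamoyl.

The series holds one measured step, an at least 1.0-fold lower number from compound 1 to compound 2 (0.01 log units; that floor lies within the scatter) and it lies on an aromatic carbon, not on the carbonyl carbon. It therefore bears on the present change only loosely, and its size gives no sign of a large move. Among the measured compounds shown here, no measured step covers the exchange at the carbonyl carbon itself. No step beyond the scatter is expected in this assay and no direction is assigned, so the estimate stays close to compound 3 at 249 ug/mL in this assay as the anchor. The estimated change is a 1.1-fold lower number from compound 3 to compound 4 (0.05 log units; within the scatter) for this exchange. Compound 4 is expected at 220 ug/mL with an estimated range of 120 ug/mL to 320 ug/mL in this assay for now.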

Compound 4, solubility: 216 ug/mL
Compound 4: middle estimate off by 1.0-fold (0.01 log units), on the high side; low and high end bracket the measured number.
By their numbers in this assay, from the lowest: compounds 4, 2 and 3 (each within the scatter of the next).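

In this assay the carbonyl carbon now carries a measured exchange of its own, and dimethylamino in place of morpholin-4-yl stays within the scatter (a 1.2-fold lower number from compound 3 to compound 4 (0.06 log units; within the scatter)), even though the group that enters has fewer heavy atoms and no ring. With dimethylcarbamoyl held fixed, the aromatic carbon also gains a step, methoxy in place of dimethylamino, which again stays within the scatter (a 1.1-fold lower number from compound 2 to compound 4 (0.03 log units; within the scatter)), so neither place has yet produced a step that can be told from repeat measurements in this assay. Compound 1 reads > 240 ug/mL (a limit and not a number), so methyl in place of hydrogen on an oxygen on an aromatic ring gives only a floor (an at least 1.1-fold lower number from compound 1 to compound 4 (0.04 log units; that floor lies within the scatter)).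

Still open, as far as these compounds go, is whether a group of another kind, such as a piperazine or a carboxylic acid on the carbonyl carbon, would give a step beyond the scatter. How far compound 1 truly stands from compounds 2, 3 and 4 also remains open: the limit of > 240 ug/mL in this assay, at which 1 of the 4 values shown sits.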